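Estimating microsomal clearance after swapping the anilide aryl group

This account rests on a few compounds, and the source may have more. Where it says the series, first, only, none or still open, it means among the compounds named here.

Of the compounds shown here, two built on a shared core have been measured in an in vitro ADME assay on microsomes from liver (Homo sapiens) for pharmacokinetics, read by LC-MS, with a stated time of 10 min, tested at 1 uM; a lower number here means slower removal, a higher number faster removal of the compound. Compound 1 `CN1C[C@H](C(=O)Nc2ccc(C(F)(F)F)cc2)[C@@H](c2ccc(/C=C/C(=O)Nc3ccccc3N)cc2)C1` gives 6 mL/min/kg in this assay. Compound 2 `CN1C[C@H](C(=O)Nc2ccc(Br)cc2)[C@@H](c2ccc(/C=C/C(=O)Nc3ccccc3N)cc2)C1` gives 3 mL/min/kg in this assay. Among the measured compounds shown here, the only recorded step, a 2.0-fold lower number from compound 1 to compound 2 (0.30 log units; within the scatter), does not exceed the scatter, so compound 2 stands at one end of two numbers that cannot be told apart with confidence, with compound 1 as its only neighbour.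

Compound 3 `Cc1cc(NC(=O)[C@H]2CN(C)C[C@@H]2c2ccc(/C=C/C(=O)Nc3ccccc3N)cc2)ccc1F` differs from compound 2 in a single place: 4-fluoro-3-methylphenyl in place of 4-bromophenyl on an amide-type nitrogen. For the measured compounds named here, no measured step covers this exact change. Going by the values given here, the one step that bears on it, a 2.0-fold lower number from compound 1 to compound 2 (0.30 log units; within the scatter), alters the same aryl group on the amide-type nitrogen and stayed within the scatter, which gives no ground to expect a step beyond the scatter in this assay for the new change either. Compound 3 is therefore expected to give a number close to that of compound 2, an estimated step of a 1.3-fold higher number from compound 2 to compound 3 (0.12 log units; within the scatter). Compound 3 is estimated at 4 mL/min/kg in this assay, within a range from 1.5 mL/min/kg to 10 mL/min/kg.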

Compound 3, clearance: 15 mL/min/kg
Compound 3: middle estimate off by 3.8-fold (0.57 log units), on the low side, outside the stated range (above it).
By their numbers in this assay, from the lowest: compounds 2 and 1 (each within the scatter of the next); then compound 3.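

On the aryl group carried by the amide-type nitrogen, this assay now shows a 5.0-fold higher number from compound 2 to compound 3 (0.70 log units; beyond the scatter) and a 2.5-fold higher number from compound 1 to compound 3 (0.40 log units; beyond the scatter); both steps lie beyond the scatter, so this position can shift clearance measurably, which the step between the two earlier compounds could not show. The change from 4-bromophenyl to 4-fluoro-3-methylphenyl keeps a six-membered aromatic ring of carbon only, with no hydrogen-bond donors or acceptors and no net charge on either group, so a shift of this size arises with those counts unchanged and only a small difference in heavy atoms. Nothing available accounts for why this exchange gives the higher number.

The compounds shown leave open whether the higher number goes with the fluorine, the methyl or the two together, a question that a 4-fluorophenyl or a 3-methylphenyl on the same nitrogen would address. They also leave open how clearance in this assay would respond if the aryl group gave way to a pyridine ring or a cyclohexyl group at this place.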